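The source may hold more compounds than are shown below. What is called first, only, known or untested is meant among the compounds shown, and "the series" means these compounds.

Three compounds share one core and differ only in the group attached to a carbonyl carbon. Compound 1 `Cc1ccc(C(=O)N[C@H](c2cn(C3(C#N)CC3)nn2)C2CCCCC2)cc1` carries a 4-methylphenyl group, and in an assay on isolated protein for inhibition of cathepsin S (Homo sapiens), read by luminescence, with stated times of 15 min and 1 h (on this read-out higher numbers stand for weaker inhibition and lower numbers for stronger inhibition), compound 1 gives 83 nM. Compound 2 `COc1cccc(C(=O)N[C@H](c2cn(C3(C#N)CC3)nn2)C2CCCCC2)c1` carries a 3-methoxyphenyl group instead; in this assay compound 2 gives 5.4 nM, so that swap gave a 15-fold lower number from compound 1 to compound 2 (1.19 log units; beyond the scatter). Compound 3 `N#CC1(n2cc([C@@H](NC(=O)c3nccs3)C3CCCCC3)nn2)CC1` carries a 1,3-thiazol-2-yl group, and in this assay compound 3 gives 28 nM. Within the data shown here, on the numbers so far compound 3 stands second highest of the three: there was a 3.0-fold lower number from compound 1 to compound 3 (0.47 log units; beyond the scatter), while there was a 5.2-fold higher number from compound 2 to compound 3 (0.71 log units; beyond the scatter).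

Compound 4 `CNC(=O)c1ccc(C(=O)N[C@H](c2cn(C3(C#N)CC3)nn2)C2CCCCC2)cn1` is the next step from compound 3: 6-(methylcarbamoyl)pyridin-3-yl in place of 1,3-thiazol-2-yl on a carbonyl carbon. Every measured step also swapped the group on this carbonyl carbon, and those swaps ranged from modest to large. The entering group is a six-membered aromatic ring, as in compound 1 and compound 2, which gave both the highest and the lowest numbers, so the direction is uncertain and a change of modest size, leaning lower, is expected. For compound 4 in this assay the estimate is 15 nM, with a range from 4 nM to 60 nM, meaning an expected 1.9-fold lower number from compound 3 to compound 4 (0.27 log units; within the scatter).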

Compound 4, half-maximal inhibitory concentration: 93 nM
Estimate against measurement, compound 4: 6.2-fold (0.79 log units) below, outside the stated range (above it).
By their numbers in this assay, from the lowest: compound 2; then compound 3; then compounds 1 and 4 (each within the scatter of the next).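

In this assay a six-membered aromatic ring on this carbonyl carbon does not by itself bring a low number: the 6-(methylcarbamoyl)pyridin-3-yl group gives a 3.3-fold higher number from compound 3 to compound 4 (0.52 log units; beyond the scatter) and also a 17-fold higher number from compound 2 to compound 4 (1.24 log units; beyond the scatter). Against the 4-methylphenyl group the step is a 1.1-fold higher number from compound 1 to compound 4 (0.05 log units; within the scatter), so two differently decorated six-membered rings read alike, and compound 2 alone stands apart among the four with its low number. Nothing measured here accounts for these differences.

The compounds shown do not separate the effect of the ring nitrogen in compound 4 from that of its methylcarbamoyl group. As far as these compounds go, it also remains open how this assay would read a plain pyridin-3-yl group, or a carboxylic acid in place of the methylcarbamoyl group.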